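Amide benzyl substituent: notes toward compound 3

This account rests on a few compounds, and the source may have more. Where it says the series, first, only, none or still open, it means among the compounds named here.

Measured so far:
compound 1 `Cc1ccccc1CNC(=O)c1nc(-c2ccc(F)cc2)n(CC[C@@H](O)C[C@@H](O)CC(=O)O)c1C1CC1`, 4850 nM
compound 2 `O=C(O)C[C@H](O)C[C@H](O)CCn1c(-c2ccc(F)cc2)nc(C(=O)NCc2ccc(F)c(F)c2)c1C1CC1`, 2780 nM

Both numbers come from a functional assay on L6 cells (Rattus norvegicus) for inhibition, read by scintillation counting, with a stated time of 3 h; a lower number here means a stronger inhibitor, a higher number a weaker inhibitor. Compound 2 sits at the low end of the two numbers shown, but its only comparison, compound 1, lies within the scatter: a 1.7-fold lower number from compound 1 to compound 2 (0.24 log units; within the scatter). On these two values compound 2 cannot be called stronger than compound 1; the pair simply reads as equivalent.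

Compound 3 `O=C(O)C[C@H](O)C[C@H](O)CCn1c(-c2ccc(F)cc2)nc(C(=O)NCc2ccccc2)c1C1CC1` is not yet measured. It differs from compound 2 at one point only: phenyl in place of 3,4-difluorophenyl on a saturated chain carbon bound to an amide-type nitrogen

Among the compounds with values here, only one measured step touches this position, the one from compound 1 to compound 2, and it stayed within the scatter. Nothing measured here separates phenyl from 3,4-difluorophenyl on the saturated chain carbon bound to the amide-type nitrogen, so no step beyond the scatter is expected in this assay from compound 2 to compound 3. The expected step is a 1.3-fold higher number from compound 2 to compound 3 (0.10 log units; within the scatter); compound 2 anchors it because 2780 nM is the nearest measured reference.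

Compound 3 is therefore estimated at 3500 nM, with a range from 1500 nM to 8000 nM.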

Compound 3, half-maximal inhibitory concentration: 632 nM
The estimate for compound 3 lay 5.5-fold (0.74 log units) above the measured number; the measured number lies below the stated range.
By their numbers in this assay, from the lowest: compound 3; then compounds 2 and 1 (each within the scatter of the next).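

In this assay the position on a saturated chain carbon bound to an amide-type nitrogen proves sensitive after all, with a 4.4-fold lower number from compound 2 to compound 3 (0.64 log units; beyond the scatter) on phenyl in place of 3,4-difluorophenyl and a 7.7-fold lower number from compound 1 to compound 3 (0.89 log units; beyond the scatter) on hydrogen in place of methyl on an aromatic carbon. Compound 1 and compound 2 had read as equivalent, which made the ring substituents look interchangeable; compound 3 now shows that each of these substituted rings, 2-methylphenyl and 3,4-difluorophenyl alike, carries a higher number than unsubstituted phenyl, and none of the three compounds goes against this. No supporting data bear on why the unsubstituted ring gives the strongest inhibitor of the three.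

The compounds shown leave open whether any substituent on this phenyl can match it, for instance a single fluorine, a chlorine, a methoxy group or an amine, or whether the higher numbers extend to every substituted ring. Also open, going by these compounds, is how much of the result depends on the benzyl group itself, which a phenethyl group or a pyridylmethyl group in its place would test.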